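Compound 4: an aromatic exchange on a flat series

The source may hold more compounds than are shown below. What is called first, only, known or untested is meant among the compounds shown, and "the series" means these compounds.

Compound 1 `COc1cccc(CNCCCNc2ccnc3cc(C4CCCCC4)ccc23)c1O` value (9.47)
Compound 2 `COc1ccc(F)cc1CNCCCNc1ccnc2cc(C3CCCCC3)ccc12` value (9.47)
Compound 3 `Fc1ccc(Cc2ccc3c(NCCCNCc4ccco4)ccnc3c2)cc1` value (9.47)

In a physicochemical assay for acid dissociation, compound 2 gives 9.47 and stands level with compound 1 at 9.47 and compound 3 at 9.47 on the digits shown. Compound 4 `COc1ccc(F)cc1CNCCCNc1ccnc2cc(-c3ccc(F)cc3)ccc12` departs from compound 2 in one place (4-fluorophenyl in place of cyclohexyl on an aromatic carbon), with 4-fluorophenyl in place of cyclohexyl on an aromatic carbon.

Among the compounds with values here, only one measured step joins two compounds that differ in a single place. This step, no change at the digits printed from compound 1 to compound 2 (within the scatter) concerns the group on a saturated chain carbon bound to an amine nitrogen, not the aromatic carbon that changes here. No measurement covers the new exchange directly, so the evidence is indirect. Compound 3 differs from compound 2 in more than one place, and compound 3 still reads 9.47 in this assay on the digits shown.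

On that basis, the expected step in this assay is none beyond the scatter, with no change at the digits printed from compound 2 to compound 4 (within the scatter) as the estimate. For compound 4 the estimated value is 9.47 with an expected range from 9.17 to 9.77 in this measurement.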

Compound 4, acid dissociation constant: 9.47
Compound 4: the middle estimate sits on the measured number at the digits printed; the range from low to high includes it.
By their numbers in this assay, from the lowest: compounds 1, 2, 3 and 4 (each within the scatter of the next).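

In this assay, the only step shown at this aromatic carbon of the fused system is no change at the digits printed from compound 2 to compound 4 (within the scatter), where 4-fluorophenyl takes the place of cyclohexyl. A six-membered non-aromatic ring of carbon only thus gives way to a six-membered aromatic ring with one more heavy atom, a fluorine, and the reading stays within the scatter. Alongside no change at the digits printed from compound 1 to compound 2 (within the scatter), at the group on a saturated chain carbon bound to an amine nitrogen, the compounds now offer one single-place step at each of two places, and neither goes beyond the scatter, although no measurement shown accounts for this flat reading.

On these data alone, both groups exchanged at this aromatic carbon have no hydrogen-bond donors or acceptors, so it remains open whether a group such as a primary amine or a carboxylic acid at the same carbon would keep the value in this assay within the scatter. Also open, as far as these compounds go, is whether a longer chain in place of the one that carries the amine nitrogen would leave the reading equally flat.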